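The compounds below may be only part of what the source reports. "The series", "measured", "known", "first", "only" and "open" are said of these compounds alone.

Compound 2 `C=CCOC[C@H]1CN(C)CC[C@@H]1c1ccc(Cl)cc1`: 20 nM. Compound 1 `CN1CC[C@H](c2ccc(Cl)cc2)[C@@H](C(=O)OC(C)(C)C)C1`: 350 nM.

In an assay on Cortex with Norepinephrine transporter (Rattus norvegicus) as the target (a lower number here means a stronger inhibitor, a higher number a weaker inhibitor), compound 2 gives 20 nM, the lowest of the two numbers, while compound 1 gives 350 nM. Compound 3 `CCOC(=O)C[C@H]1CN(C)CC[C@@H]1c1ccc(Cl)cc1` differs from compound 2 by ethoxycarbonyl in place of allyloxy on a saturated chain carbon bound to a saturated ring carbon. For the measured compounds named here, the one measured step that bears on this is an 18-fold lower number from compound 1 to compound 2 (1.24 log units; beyond the scatter), where an ether took the place of an ester and the number fell sharply; compound 3 carries an ester again, as (ethoxycarbonyl)methyl. A rise is therefore expected, estimated as a 5.0-fold higher number from compound 2 to compound 3 (0.70 log units; beyond the scatter). For compound 3 the expected value is 100 nM, with a range from 30 nM to 350 nM.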

Compound 3, inhibition constant: 101 nM
Compound 3: the middle estimate sits 1.0-fold (0.00 log units) below what was measured; measured number inside the range.
By their numbers in this assay, from the lowest: compound 2; then compound 3; then compound 1.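

In this assay, ethoxycarbonyl in place of allyloxy on a saturated chain carbon bound to a saturated ring carbon gives a 5.1-fold higher number from compound 2 to compound 3 (0.70 log units; beyond the scatter) and so costs potency. Having an ester does not settle the number on its own, though: (ethoxycarbonyl)methyl in place of tert-butoxycarbonyl gives a 3.5-fold lower number from compound 1 to compound 3 (0.54 log units; beyond the scatter) even though both compounds carry an ester. Going by these compounds, whether an amide or a carboxylic acid at this place would fall nearer compound 2 or compound 1 stays open. No measurement shown explains either step.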